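A few compounds are considered here, and "the series" means these few. Any claim that something is new, unique, unknown or untested is made for them only; others in the source may bear on it.

In a functional assay on A549 cells (Homo sapiens) for antiproliferative activity, read by MTT assay, with a stated time of 72 h (on this read-out lower numbers stand for stronger inhibition and higher numbers for weaker inhibition), compound 1 `FC(F)(F)c1ccc(COc2cccc(Nc3ncnc4cc5c(cc34)OCCOCCOCCO5)c2)cc1` gives 24900 nM. For the measured compounds named here, compound 2 `c1ccc(COc2ccccc2Nc2ncnc3cc4c(cc23)OCCOCCO4)cc1` carries a related core with a shorter ether chain and a plain benzyloxy group, and no single-change step joins it to compound 1. For compound 2 the result in this assay is a limit of the assay rather than a number, > 100000 nM, as recorded in the limit of > 100000 nM in this assay, at which 1 of the 2 values shown sits. Compound 3 `O=[N+]([O-])c1ccc(COc2ccccc2Nc2ncnc3cc4c(cc23)OCCOCCO4)cc1` differs from compound 2 only by nitro in place of hydrogen on an aromatic carbon. Going by the values given here, no measured pair in this set shows what such a change does in this assay, so the expectation rests on the structures alone. The step is expected to be an at least 1.4-fold lower number from compound 2 to compound 3 (0.15 log units; that floor lies within the scatter), modest and, if anything, toward stronger inhibition, though it may not exceed the scatter. Compound 3 is therefore estimated at 70000 nM, with a range from 20000 nM to 200000 nM, and a fair chance that it too returns only a limit.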

Compound 3, half-maximal inhibitory concentration: 28400 nM
Compound 3: middle estimate off by 2.5-fold (0.39 log units), on the high side; the measured number falls inside the stated range.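

Placing nitro on the ring of the benzyloxy group, para to a large group, moves the result in this assay from a limit to a measured number: the change gives an at least 3.5-fold lower number from compound 2 to compound 3 (0.54 log units; beyond the scatter). This shows that this position responds to a substituent, and that the response runs toward stronger inhibition, beyond the scatter. From the compounds shown here alone, compound 2 is recorded only as a limit, so the step is a floor and its full size stays unknown, because one end of it is not a number: the limit of > 100000 nM in this assay, at which 1 of the 3 values shown sits.

With a single substituent at this position, the compounds leave open whether the gain is particular to nitro or would also appear with an amine, a methoxy group or a carboxylic acid in the same place. They also leave open whether the 4-nitrobenzyl group would give a similar step on the core of compound 1, with its longer ether chain.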